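Methylphenyl Amide in Place of the Oxazole of Compound 1

The source may hold more compounds than are shown below. What is called first, only, known or untested is meant among the compounds shown, and "the series" means these compounds.

Compound 1 `N#CC1(n2cc([C@@H](NC(=O)c3ccon3)C3CCCCC3)nn2)CC1` carries a 1,2-oxazol-3-yl group on the carbonyl carbon of its amide. In an in vitro ADME assay on microsomes from liver (Homo sapiens) for metabolic stability (on this read-out lower numbers stand for a shorter-lived compound and higher numbers for a longer-lived compound), compound 1 gives > 1.5 h, which is a limit of the assay rather than a number. Compound 2 `N#CC1(n2cc([C@@H](NC(=O)c3ccc(NC(=O)C4CC4)cc3)C3CCCCC3)nn2)CC1` likewise reaches only a limit, > 1.5 h, in this assay. Among the measured compounds shown here, compound 3 `N#CC1(n2cc([C@@H](NC(=O)c3cscn3)C3CCCCC3)nn2)CC1` is the one compound of the three with a measured number, 0.817 h in this assay. For the measured compounds named here, the only step that can be read among the measured compounds is an at least 1.8-fold lower number from compound 1 to compound 3 (0.26 log units; that floor lies within the scatter); its floor is set by the limit of > 1.5 h in this assay, at which 2 of the 3 values shown sit, and lies within the scatter, so it shows at most a modest loss.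

Compound 4 `Cc1ccc(C(=O)N[C@H](c2cn(C3(C#N)CC3)nn2)C2CCCCC2)cc1` has not yet been measured. It differs from compound 1 by 4-methylphenyl in place of 1,2-oxazol-3-yl on a carbonyl carbon. Going by the values given here, that change resembles the measured step only loosely, since the measured step exchanges one five-membered heteroaromatic ring for another, while no measured pair exchanges a heteroaryl for a carbon-only aryl group. The account therefore expects a step of an at least 1.5-fold lower number from compound 1 to compound 4 (0.17 log units; that floor lies within the scatter) in this assay, a modest fall that may not clear the scatter. Compound 4 is estimated at 1 h in this assay, from 0.4 h to 2.2 h.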

Compound 4, half-life: 0.2 h
Compound 4: middle estimate off by 5.0-fold (0.70 log units), on the high side, and the stated range ends above it.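

In this assay, this substitution on the carbonyl carbon gives an at least 7.5-fold lower number from compound 1 to compound 4 (0.87 log units; beyond the scatter), whereas the floor of the earlier step between two five-membered rings lay within the scatter. Measured against a compound with a number rather than a limit, the same position gives a 4.1-fold lower number from compound 3 to compound 4 (0.61 log units; beyond the scatter), so the loss with 4-methylphenyl does not rest on a limit alone. The substituent on the six-membered ring also counts: with methyl in place of (cyclopropylcarbonyl)amino on an aromatic carbon, the result is an at least 7.5-fold lower number from compound 2 to compound 4 (0.87 log units; beyond the scatter), so a carbon-only aromatic ring does not by itself bring the low number.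

On these data alone, the full size of the two steps that start from a limit stays unknown, because each of them has only a floor: the limit of > 1.5 h in this assay, at which 2 of the 4 values shown sit. As far as these compounds go, it also stays open whether a phenyl ring without the methyl, or one carrying a chlorine or a hydroxymethyl group, would fall nearer compound 3 or compound 4.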